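Compound 3 to Compound 4: One Carbon More on Piperazine

This account rests on a few compounds, and the source may have more. Where it says the series, first, only, none or still open, it means among the compounds named here.

Measured so far in an assay on HeLa cells for displacement of a labelled ligand from 5-hydroxytryptamine receptor 6 (Homo sapiens); on this read-out lower numbers stand for stronger inhibition and higher numbers for weaker inhibition:
Compound 1 `CC(C)c1ccc(S(=O)(=O)n2cc(N3CCN(C)CC3)c3ccc(Cl)cc32)cc1` gives 55.3 nM.
Compound 2 `CN1CCN(c2cn(S(=O)(=O)c3ccccc3Br)c3ccc(Br)cc23)CC1` gives 10.2 nM.
Compound 3 `CN1CCN(c2cn(S(=O)(=O)c3ccc(F)cc3)c3ccc(Br)cc23)CC1` gives 9.2 nM.

Compound 3 shows the lowest number of the three. Compound 2 sits within the scatter of it, as the step of a 1.1-fold lower number from compound 2 to compound 3 (0.04 log units; within the scatter) shows. Compound 1 is the furthest away, with a clearly higher number than compound 3.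

Compound 4 `CCN1CCN(c2cn(S(=O)(=O)c3ccc(F)cc3)c3ccc(Br)cc23)CC1` differs from compound 3 by methyl in place of hydrogen on a saturated chain carbon bound to an amine nitrogen in a ring; cut one bond further out, this reads methyl to ethyl, 4-methylpiperazin-1-yl to 4-ethylpiperazin-1-yl. Among the compounds with values here, the only measured step, from compound 2 to compound 3, alters the group on the sulfonyl sulfur, not this position, so no measured step bears on the change. Lacking such guidance, compound 4 is expected to stay near compound 3, with a step of a 1.1-fold higher number from compound 3 to compound 4 (0.04 log units; within the scatter). Compound 4 is therefore estimated at 10 nM, within a range from 4 nM to 25 nM.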

Compound 4, inhibition constant: 10.6 nM
Compound 4: middle estimate off by 1.1-fold (0.03 log units), on the low side; low and high end bracket the measured number.
By their numbers in this assay, from the lowest: compounds 3, 2 and 4 (each within the scatter of the next); then compound 1.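

Compound 4 gives the first measured step at the piperazine end of these compounds. In this assay, going from 4-methylpiperazin-1-yl to 4-ethylpiperazin-1-yl gives a 1.2-fold higher number from compound 3 to compound 4 (0.06 log units; within the scatter). So one added carbon at this position leaves the number within the usual scatter, and no measurement shown here offers a reason for that.

Going by these compounds, whether a longer chain such as propyl or butyl would fit as well remains open. The same holds for a benzyl group or a chain ending in a hydroxyl.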